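From Fluoro to Nitro: Expecting the Cytotoxicity of Compound 4

The source may hold more compounds than are shown below. What is called first, only, known or untested is meant among the compounds shown, and "the series" means these compounds.

Of the compounds shown here, three sharing one core have been measured in a functional assay on HepG2 cells (Homo sapiens) for cytotoxicity, read by MTT assay, with a stated time of 72 h; a lower number here means a stronger inhibitor, a higher number a weaker inhibitor. Compound 1 `O=C1C=CCC/C1=C\C=C\c1ccccc1` gives 7100 nM. Compound 2 `CC(=C\c1ccccc1)/C=C1\CCC=CC1=O`, which carries a methyl in place of hydrogen on a double-bonded chain carbon bound to two double-bonded chain carbons, gives 4600 nM; the step is a 1.5-fold lower number from compound 1 to compound 2 (0.19 log units; within the scatter). Compound 3 `O=C1C=CCC/C1=C\C=C\c1ccc(F)cc1`, with fluoro in place of hydrogen on an aromatic carbon, gives 2900 nM, and the step is a 2.4-fold lower number from compound 1 to compound 3 (0.39 log units; beyond the scatter). Compound 3 thus has the lowest of the three numbers, although only its gap to compound 1 lies beyond the scatter; its gap to compound 2 does not.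

Compound 4 `O=C1C=CCC/C1=C\C=C\c1ccc([N+](=O)[O-])cc1` has not yet been measured. It differs from compound 3 in one place: nitro in place of fluoro on an aromatic carbon. Among the compounds with values here, the only measured step touching that aromatic carbon is the one from compound 1 to compound 3, where fluoro replaced hydrogen and gave a modest lowering of the number; nothing measured shows what a nitro group does at that place. With so little to rest on, the expected step is small, a 1.3-fold lower number from compound 3 to compound 4 (0.12 log units; within the scatter), and could fall on either side. Compound 4 is therefore estimated at 2200 nM, with a range from 800 nM to 6500 nM.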

Compound 4, half-maximal inhibitory concentration: 4900 nM
Estimate against measurement, compound 4: 2.2-fold (0.35 log units) below; measured number inside the range.
By their numbers in this assay, from the lowest: compounds 3, 2, 4 and 1 (each within the scatter of the next, the first and the last beyond it).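

In this assay, this aromatic carbon, para to a large group, accepts a much larger group than fluoro without a clear shift: nitro brings three heavy atoms in place of one, and two hydrogen-bond acceptors where fluoro has none, yet the change gives (a 1.7-fold higher number from compound 3 to compound 4 (0.23 log units; within the scatter)). The earlier compounds shown here showed only that fluoro in place of hydrogen gives a step beyond the scatter (a 2.4-fold lower number from compound 1 to compound 3 (0.39 log units; beyond the scatter)), whereas nitro in place of hydrogen stays within it (a 1.4-fold lower number from compound 1 to compound 4 (0.16 log units; within the scatter)), so the lowering seen with fluoro does not clearly carry over to nitro. Nothing available here explains these numbers.

With only hydrogen, fluoro and nitro shown at this carbon, it stays open whether any group there can take the number clearly below that of compound 3, for example an amine, a carboxylic acid or a longer chain. From the compounds shown here alone, it also stays open whether the methyl on the chain of compound 2, whose own step lies within the scatter, would change anything when combined with fluoro or nitro on the aromatic ring.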